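A Second Hydroxy on a Weak Inhibitor

This account rests on a few compounds, and the source may have more. Where it says the series, first, only, none or still open, it means among the compounds named here.

Compound 1 `Cc1c2c(cc(C(C)C)cc1=O)[C@@H](C)CC2`: > 30000 nM (a limit)
Compound 2 `Cc1c2c(cc(C(C)C)cc1=O)[C@@H](C)C[C@H]2O`: 26000 nM

Among the compounds with values here, in a functional assay on BV-2 cells (Mus musculus) for inhibition, read by Griess assay, with a stated time of 24 h (a lower number here means a stronger inhibitor, a higher number a weaker inhibitor), compound 2 gives 26000 nM, the only actual number so far. For compound 1, > 30000 nM is a limit, as the limit of > 30000 nM in this assay, at which 1 of the 2 values shown sits, records. Compound 3 `CC(C)c1cc2c(c(CO)c(=O)c1)[C@H](O)C[C@@H]2C` differs from compound 2 by hydroxy in place of hydrogen on a saturated chain carbon bound to an aromatic carbon, turning methyl to hydroxymethyl. Within the data shown here, one measured step bears on this: an at least 1.1-fold lower number from compound 1 to compound 2 (0.06 log units; that floor lies within the scatter). It also placed hydroxy in place of hydrogen, though on a saturated ring carbon. No step beyond the scatter is therefore expected in this assay. The estimated step is a 1.1-fold lower number from compound 2 to compound 3 (0.03 log units; within the scatter). Compound 3 is expected at 24000 nM, within an estimated range of 10000 nM to 50000 nM.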

Compound 3, half-maximal inhibitory concentration: 9000 nM
For compound 3 the middle estimate is 2.7-fold (0.43 log units) above the measured one; the measured number lies below the stated range.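

In this assay, the change from methyl to hydroxymethyl on the saturated chain carbon bound to an aromatic carbon gives a 2.9-fold lower number from compound 2 to compound 3 (0.46 log units; beyond the scatter), the only step shown that lies beyond the scatter. The hydroxy on a saturated ring carbon gave only an at least 1.1-fold lower number from compound 1 to compound 2 (0.06 log units; that floor lies within the scatter), a step that rests on a limit. Nothing at hand accounts for the gain at this position.

Going by these compounds, whether an amine or a carboxylic acid at this position would do the same remains open, as does whether hydroxymethyl gives this step without the ring hydroxy.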